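The source may report more compounds than this note shows. Statements on the series, on what has been measured and on what is new or still open speak of the compounds shown alone.

Measured compounds:
- compound 1 `CCOC(=O)C1=CC(c2ccc(Br)cc2)C2=C(CC(C)(C)CC2=O)N1` gives "not active" (no number reported)
- compound 2 `CC1(C)CC(=O)C2=C(C1)NC(c1ccccc1)=CC2c1ccco1` gives 11.4%

Of the compounds shown here, two sharing the same core have been tested in an assay on isolated protein for inhibition of glucose-6-phosphatase catalytic subunit 1 (Homo sapiens), read by inositol phosphate accumulation, with a stated time of 30 min, tested at 100 uM; a higher number here means more inhibition at the concentration tested (going by the name of the read-out), a lower number less inhibition. Compound 1 `CCOC(=O)C1=CC(c2ccc(Br)cc2)C2=C(CC(C)(C)CC2=O)N1` was reported in this assay as "not active" (no number reported), with no number attached, so it stands without a single value to place it on the scale. Compound 2 `CC1(C)CC(=O)C2=C(C1)NC(c1ccccc1)=CC2c1ccco1` gives 11.4% in this assay, a small read-out that, on its own, shows only weak inhibition at the concentration tested. Going by the values given here, nothing can be said of a step between compound 1 and compound 2, since no common pair is known and the two differ in more than one place.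

The account now turns to compound 3 `CCOC(=O)C1=CC(c2ccc(Cl)cc2)C2=C(CC(C)(C)CC2=O)N1`, which is yet to be measured in this assay. It differs from compound 1 in one place: chloro in place of bromo on an aromatic carbon. Read one bond further out, 4-bromophenyl becomes 4-chlorophenyl. Among the compounds with values here, with compound 1 reported as inactive and no step between measured compounds to lean on, the exchange is expected to move the read-out by no more than the usual scatter, in no particular direction. Compound 3 is therefore estimated to give 5% in this assay, within a range from -8% to 22%.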

Compound 3, a percentage reported as inhibition, at one concentration (the size of the read-out at that concentration, not a potency): 11.3%
The estimate for compound 3 lay 6.3 percentage points below the measured number; the measured number falls inside the stated range.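

Going by these compounds alone, compound 1 stands in this assay without a number, so no step from compound 1 to compound 3 can be read from this result. The compounds shown leave open whether 4-bromophenyl and 4-chlorophenyl differ at all in this read-out on the shared core. No evidence at hand bears on the result.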